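The source may report more compounds than this note shows. Statements on the series, on what has been measured and on what is new or still open speak of the compounds shown alone.

Compound 1 `CN(C)C(=O)c1cc2cnc(Nc3ccc(C(=O)NCCCCCN=C=S)cc3)nc2n1C1CCCC1` stands second highest of the three numbers in a functional assay on A549 cells (Homo sapiens) for inhibition, read by CCK-8 assay, with a stated time of 72 h, tested at 1 uM (on this read-out lower numbers stand for a weaker effect and higher numbers for a stronger effect at the one concentration tested), where compound 1 gives 29.3%. Compound 2 `CN(C)C(=O)c1cc2cnc(Nc3ccc(C(=O)NCCCCCCCN=C=S)cc3)nc2n1C1CCCC1` gives 73.7% and compound 3 `CN(C)C(=O)c1cc2cnc(Nc3ccc(C(=O)NCCCCCN=C=S)cc3F)nc2n1C1CCCC1` gives -1.6%. Compound 4 `CN(C)C(=O)c1cc2cnc(Nc3ccc(N=C=S)cc3)nc2n1C1CCCC1` differs from compound 1 in one place: a group of 3 heavy atoms (1 carbon, 1 nitrogen, 1 sulfur; no ring) in place of a group of 11 heavy atoms (7 carbon, 2 nitrogen, 1 oxygen, 1 sulfur; no ring), on an aromatic carbon. For the measured compounds named here, two measured steps bear on this. Lengthening the chain that carries the isothiocyanate gave a number 44.4 percentage points higher from compound 1 to compound 2 (beyond the scatter), so taking that chain away altogether may pull the number the other way; the step of a number 30.9 percentage points lower from compound 1 to compound 3 (beyond the scatter) shows that a change on the aromatic ring can also cut the effect sharply. Compound 4 is therefore expected to land lower, with a number 19.3 percentage points lower from compound 1 to compound 4 (beyond the scatter), at an estimated 10% within a range of -15% to 40%.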

Compound 4, a percentage reported as inhibition, at one concentration (the size of the read-out at that concentration, not a potency): 44.4%
For compound 4 the middle estimate is 34.4 percentage points below the measured one; the measured number lies above the stated range.
By their numbers in this assay, from the lowest: compound 3; then compound 1; then compound 4; then compound 2.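

In this assay, setting the isothiocyanate directly on the aromatic carbon, with no amide-bearing chain, gives a number 15.1 percentage points higher from compound 1 to compound 4 (beyond the scatter). The effect at this position therefore does not depend on that chain, and the number does not simply fall as the chain gets shorter: the chain of compound 1 gives less than no chain at all. Nothing available explains this rise.

On these data alone, it remains open whether an amine or a carboxylic acid at this aromatic carbon would keep the effect. A fluoro on the ring of compound 4 might also cut the number, as it does for compound 3.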